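A Trifluoromethyl Swap on Compound 3

The source may hold more compounds than are shown below. What is called first, only, known or untested is meant among the compounds shown, and "the series" means these compounds.

For the measured compounds named here, in an ADME assay on microsomes from liver (Homo sapiens) for metabolic stability (on this read-out lower numbers stand for slow clearance and higher numbers for fast clearance), compound 3 (`CCCC(Oc1ccc(-n2cc3c(n2)CCCC3)cc1)c1ccc(C(=O)NCCC(=O)O)cc1`) gives 48 mL/min/kg as the higher of the two exact numbers so far. Compound 2 (`O=C(O)CCNC(=O)c1ccc(C(Oc2ccc(-n3cc(C(F)(F)F)cn3)cc2)C2CCCC2)cc1`) gives 22 mL/min/kg as the other, and that gap lies beyond the scatter. Compound 1 (`CCCC(Oc1ccc(-n2cc(C(=O)N(C)C)cn2)cc1)c1ccc(C(=O)NCCC(=O)O)cc1`) gives < 13 mL/min/kg as a limit of the assay and not a number.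

Compound 4 (`CCCC(Oc1ccc(-n2cc(C(F)(F)F)cn2)cc1)c1ccc(C(=O)NCCC(=O)O)cc1`) differs from compound 3 in one place, with a group of 9 heavy atoms (4 carbon, 2 nitrogen, 3 fluorine; one five-membered aromatic ring with 2 hetero atoms) in place of a group of 9 heavy atoms (7 carbon, 2 nitrogen; one five-membered aromatic ring with 2 hetero atoms, one six-membered non-aromatic ring of carbon only), on an aromatic carbon as the count. The group that enters is 4-(trifluoromethyl)-1H-pyrazol-1-yl, para to a large group, and the six-membered non-aromatic ring of carbon only is gone.

Two measurements bear on this change. Going by the values given here, the step of an at least 3.6-fold higher number from compound 1 to compound 3 (0.56 log units; beyond the scatter) is the only measured change at this same place, and it ends at the group that compound 4 gives up. It shows that a swap here can move the number beyond the scatter. Differing from compound 4 elsewhere, compound 2 carries the entering group and gives 22 mL/min/kg as the closest guide.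

A fall in clearance is therefore expected, with an estimated 2.2-fold lower number from compound 3 to compound 4 (0.34 log units; beyond the scatter) as its likely size in this assay terms. For compound 4 the expected clearance is 22 mL/min/kg with an estimated range from 11 mL/min/kg to 42 mL/min/kg on this read-out.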

Compound 4, clearance: 16 mL/min/kg
Estimate against measurement, compound 4: 1.4-fold (0.14 log units) above; the range from low to high includes it.
By their numbers in this assay, from the lowest: compounds 4 and 2 (each within the scatter of the next); then compound 3. At a limit, below all of these: compound 1.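

In this assay, for the compounds shown here, the 4-(trifluoromethyl)-1H-pyrazol-1-yl group, entering in place of the group with the six-membered non-aromatic ring of carbon only, gives a 3.0-fold lower number from compound 3 to compound 4 (0.48 log units; beyond the scatter) and so shows that a swap at this place can lower the number, whereas an at least 3.6-fold higher number from compound 1 to compound 3 (0.56 log units; beyond the scatter) was the only earlier step here and it raised the number. At another place, propyl in place of cyclopentyl gives a 1.4-fold lower number from compound 2 to compound 4 (0.14 log units; within the scatter) and so cannot be told from the scatter, which means that with trifluoromethyl present, this chain swap shows no measurable effect on clearance. The step of an at least 1.2-fold higher number from compound 1 to compound 4 (0.09 log units; that floor lies within the scatter) with trifluoromethyl in place of dimethylcarbamoyl starts from a limit and not a number, so it gives only a floor and does not separate these two groups: the limit of < 13 mL/min/kg in this assay, at which 1 of the 4 values shown sits.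

The compounds shown leave open whether a smaller group such as methyl or a nitrile, set in place of trifluoromethyl on the pyrazole, would keep the number close to that of compound 4 or move it toward that of compound 3. They also leave open whether a butyl chain or a cyclopropyl ring, set in place of propyl, would stay within the scatter as cyclopentyl did.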